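Cyclopentyl for Butyl on an Amide Nitrogen

The source may hold more compounds than are shown below. What is called first, only, known or untested is meant among the compounds shown, and "the series" means these compounds.

Compound 2 `CCCCNC(=O)CC1CCc2cc(OC)c(OC)cc21` was tested in a functional assay on the whole organism (strain Wistar) for inhibition, with Rattus norvegicus as the target, read by paw edema, with stated times of 60 min and 6 h, at a dose of 100 mg/kg by the oral route (on this read-out higher numbers stand for more inhibition at the one dose given (going by the name of the read-out) and lower numbers for less inhibition), where compound 2 gives 24.1%. Within the data shown here, its companion compound 1 `COc1cc2c(cc1OC)C(CC(=O)O)CC2` gives 20.4% in this assay, and the one recorded step, a number 3.7 percentage points higher from compound 1 to compound 2 (within the scatter), lies within the scatter, so these two numbers cannot be told apart. Compound 3 `COc1cc2c(cc1OC)C(CC(=O)NC1CCCC1)CC2` has not yet been measured. It differs from compound 2 by cyclopentyl in place of butyl on an amide-type nitrogen. Among the measured compounds shown here, no measured step touches the group on the amide nitrogen; the only step available, a number 3.7 percentage points higher from compound 1 to compound 2 (within the scatter), concerns the substituent on the carbonyl carbon and stayed within the scatter. With nothing pointing up or down, no change beyond the scatter is expected in this assay, and the step of a number 0.9 percentage points higher from compound 2 to compound 3 (within the scatter) is expected to be small. For compound 3 the estimate in this assay is 25%, with a range from 12% to 38%.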

Compound 3, a percentage reported as inhibition, in the whole organism at one dose (the size of the read-out at that dose, not a potency): 40.7%
For compound 3 the middle estimate is 15.7 percentage points below the measured one, and the stated range ends below it.
By their numbers in this assay, from the lowest: compounds 1 and 2 (each within the scatter of the next); then compound 3.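

In this assay, among these compounds, the group on the amide nitrogen proves able to move the number, which the earlier pair could not show: the step of a number 16.6 percentage points higher from compound 2 to compound 3 (beyond the scatter) is the first at this position and lies beyond the scatter. Butylamino in place of hydroxy on the carbonyl carbon had stayed within the scatter, while the step of a number 20.3 percentage points higher from compound 1 to compound 3 (beyond the scatter) lies beyond it, so among these compounds the change from the acid reaches beyond the scatter with cyclopentylamino and not with the butylamino of compound 2. Nothing available accounts for the difference between the two groups.

From the compounds shown here alone, whether the ring as such carries the step or any compact group would do stays open, and a cyclohexyl or an isopropyl group on the same nitrogen would bear on that. Going by these compounds, how an amine with a second substituent on this nitrogen would read also remains unknown.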